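The source may report more compounds than this note shows. Statements on the series, on what has been measured and on what is new or still open speak of the compounds shown alone.

Series notes. Compound 3 `COc1ccc(N(CC(=O)NCCCSc2ccccc2)C(=O)c2ccccc2)cc1` stands at the limit of a functional assay on A-431 cells (Homo sapiens) for cytotoxicity, read by MTT assay, with a stated time of 24 h; on this read-out lower numbers stand for stronger inhibition and higher numbers for weaker inhibition: in this assay compound 3 gives >= 100000 nM, which is a limit rather than a number. Compound 2 `COc1ccc(N(CC(=O)NCCC[Se]c2ccccc2)C(=O)c2ccccc2)cc1` likewise sits at a limit, as in this assay compound 2 gives >= 100000 nM. Compound 1 `COc1ccc(N(CC(=O)NCCC[Te]c2ccccc2)C(=O)CNC(=O)OC(C)(C)C)cc1` differs in the acyl part, and in this assay compound 1 gives 5000 nM. Among the measured compounds shown here, the only measured step, a step that the two limits leave unreadable from compound 2 to compound 3, cannot be read, and the limit of >= 100000 nM in this assay, at which 2 of the 3 values shown sit, shows where the values stop. Compound 4 `COc1ccc(N(CC(=O)NCCC[Te]c2ccccc2)C(=O)c2ccccc2)cc1` carries a group of 7 heavy atoms (6 carbon, 1 tellurium; one six-membered aromatic ring of carbon only) in place of a group of 7 heavy atoms (6 carbon, 1 sulfur; one six-membered aromatic ring of carbon only), on a saturated chain carbon, three bonds along the chain from an amide-type nitrogen. For the measured compounds named here, no measured step covers this change, so its direction is open; the one tellurium compound on hand is compound 1 at 5000 nM, with a different acyl group. Compound 4 is therefore expected at 20000 nM, between 3000 nM and 100000 nM, an estimated step of an at least 5.0-fold lower number from compound 3 to compound 4 (0.69 log units; beyond the scatter).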

Compound 4, half-maximal inhibitory concentration: 5000 nM
The estimate for compound 4 lay 4.0-fold (0.60 log units) above the measured number; measured number inside the range.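

Series notes, continued. In this assay, among the compounds shown here, the phenyl group carrying tellurium gives the first readable change at this place, with an at least 20-fold lower number from compound 3 to compound 4 (1.30 log units; beyond the scatter) and an at least 20-fold lower number from compound 2 to compound 4 (1.30 log units; beyond the scatter). These steps have only a lower bound on their size, and the step between the sulfur and selenium compounds cannot be read: the limit of >= 100000 nM in this assay, at which 2 of the 4 values shown sit. The acyl exchange, phenyl in place of ((tert-butoxycarbonyl)amino)methyl on a carbonyl carbon, shows no change at the digits printed from compound 1 to compound 4 (within the scatter), so these two tellurium compounds do not separate.

Going by these compounds, how far compound 2 and compound 3 lie past the limit remains open. Also open, on these data alone, is whether a longer chain between the amide nitrogen and the tellurium keeps this reading.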